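Moving the chlorine on a benzyl group: a predicted step

This account rests on a few compounds, and the source may have more. Where it says the series, first, only, none or still open, it means among the compounds named here.

Of the compounds shown here, three have been tested in a physicochemical assay, read by spectrophotometry, with a stated time of 30 min; a higher number here means a weaker inhibitor, a lower number a stronger inhibitor. Compound 1 `Cc1ccc(OCc2cn(Cc3ccc(Cl)cc3)nn2)cc1` gives 17.3 ug/mL in this assay. Compound 2 `Cc1ccc(OCc2cn(Cc3cccc(Cl)c3)nn2)cc1` gives 16.3 ug/mL. Compound 3 `O=[N+]([O-])c1cccc(OCc2cn(Cc3ccc(Cl)cc3)nn2)c1` gives 37.3 ug/mL, the highest of the three numbers, beyond the scatter from both others. The difference between the core of compound 3 and that of compound 1 is not broken down here.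

Compound 2 differs from compound 1 by 3-chlorophenyl in place of 4-chlorophenyl on a saturated chain carbon bound to an aromatic nitrogen, and this gave a 1.1-fold lower number from compound 1 to compound 2 (0.03 log units; within the scatter). Compound 4 `O=[N+]([O-])c1cccc(OCc2cn(Cc3cccc(Cl)c3)nn2)c1` is not yet measured; it differs from compound 3 by the same kind of change, (3-chlorophenyl in place of 4-chlorophenyl on a saturated chain carbon bound to an aromatic nitrogen), in the same place.

Because the change from compound 1 to compound 2 gave a 1.1-fold lower number from compound 1 to compound 2 (0.03 log units; within the scatter), a step of similar size is expected from compound 3 to compound 4, namely a 1.1-fold lower number from compound 3 to compound 4 (0.03 log units; within the scatter). Compound 4 is therefore estimated at 35 ug/mL in this assay, with the likely range running from 20 ug/mL to 65 ug/mL, resting on a single earlier example of this change.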

Compound 4, half-maximal inhibitory concentration: 31.2 ug/mL
For compound 4 the middle estimate is 1.1-fold (0.05 log units) above the measured one; the range from low to high includes it.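

In this assay moving the chlorine from 4-chlorobenzyl to 3-chlorobenzyl gave a 1.2-fold lower number from compound 3 to compound 4 (0.08 log units; within the scatter) on the core of compound 3, and the same change gave a 1.1-fold lower number from compound 1 to compound 2 (0.03 log units; within the scatter) on the core of compound 1, so in neither pair can the two compounds be told apart. The change therefore carried across these two cores without producing a step beyond the scatter, but two pairs cannot show that the place of the chlorine makes no difference on other cores or in other tests. Nothing available explains the result, and no independent measurement bears on it.

The compounds shown leave open whether the step stays this small on cores that carry a different group in place of the methyl of compound 1 or the nitro of compound 3, such as an amine or a carboxylic acid. They also leave open what happens when the chlorine gives way to fluorine or a methoxy group, or when a longer chain replaces the single carbon of the benzyl group.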